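The source may hold more compounds than are shown below. What is called first, only, known or untested is meant among the compounds shown, and "the series" means these compounds.

Among the measured compounds shown here, compound 3 `COc1ccc(C(=O)Nc2ccc(C(=O)/C=C/c3nc(C)c(C)nc3C)cc2)cc1` gives 1190 nM in a functional assay on HepG2 cells (Homo sapiens) for antiproliferative activity, read by CCK-8 assay, with a stated time of 72 h (a lower number here means a stronger inhibitor, a higher number a weaker inhibitor), the lowest of the three numbers so far. Compound 1 `Cc1ccc(C(=O)Nc2ccc(C(=O)/C=C/c3nc(C)c(C)nc3C)cc2)cc1` gives 5450 nM and compound 2 `Cc1nc(C)c(/C=C/C(=O)c2ccc(NC(=O)c3ccc(F)cc3F)cc2)nc1C` gives 2990 nM; the steps into compound 3 are a 4.6-fold lower number from compound 1 to compound 3 (0.66 log units; beyond the scatter) and a 2.5-fold lower number from compound 2 to compound 3 (0.40 log units; beyond the scatter), whereas a 1.8-fold lower number from compound 1 to compound 2 (0.26 log units; within the scatter). Compound 4 `Cc1nc(C)c(/C=C/C(=O)c2ccc(NC(=O)c3ccc(F)cc3)cc2)nc1C` differs from compound 3 by fluoro in place of methoxy on an aromatic carbon. For the measured compounds named here, no measured pair sets methoxy against fluoro directly; the two steps that bear on the change are those into compound 3, in which 4-methoxyphenyl on the carbonyl carbon gave the lower number both against 4-methylphenyl and against 2,4-difluorophenyl. For compound 4 a modestly higher number than compound 3 is therefore expected, because the methoxy removed in compound 4 is the group whose entry gave a 4.6-fold lower number from compound 1 to compound 3 (0.66 log units; beyond the scatter), and the outcome is expected to fall between compound 3 and compound 2. The expected step is a 2.1-fold higher number from compound 3 to compound 4 (0.32 log units; beyond the scatter). Compound 4 is expected to give 2500 nM, with a range of 1200 nM to 5500 nM.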

Compound 4, half-maximal inhibitory concentration: 2250 nM
Beside the measured number, compound 4's estimate is 1.1-fold (0.05 log units) above it; the measured number falls inside the stated range.
By their numbers in this assay, from the lowest: compounds 3, 4, 2 and 1 (each within the scatter of the next, the first and the last beyond it).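

In this assay, among the compounds shown here, a 1.9-fold higher number from compound 3 to compound 4 (0.28 log units; within the scatter) leaves methoxy and fluoro on this aromatic carbon unseparated, so methoxy is no longer the only group set apart from methyl: a 2.4-fold lower number from compound 1 to compound 4 (0.38 log units; beyond the scatter) shows that fluoro in place of methyl also goes beyond the scatter. Removing the second fluoro of the 2,4-difluorophenyl group gives a 1.3-fold lower number from compound 2 to compound 4 (0.12 log units; within the scatter), so that fluoro makes no readable difference. Compound 2 goes against any rule that fluoro on the ring is enough, since it stays within the scatter of compound 1, and the separation from methyl holds only for compound 3 and compound 4.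

On these data alone, it remains open whether an amine or a carboxylic acid on this aromatic carbon would give a number clearly apart from those of methoxy and fluoro. Nothing available explains why these groups compare as they do.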